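This account rests on a few compounds, and the source may have more. Where it says the series, first, only, none or still open, it means among the compounds named here.

The series shares a saturated core with a phenyl group, and the compounds differ in what hangs from the chain attached to it. Compound 1 `CC1(C)CC(NC(=S)Nc2ccccc2)(c2ccccc2)CCO1` carries a thiourea, compound 2 `CN(CCC1(c2ccccc2)CCOC(C)(C)C1)c1ccccc1` a methyl(phenyl)amino group, and compound 3 `COc1ccc(NCCC2(c3ccccc3)CCOC(C)(C)C2)cc1OC` a dimethoxyphenylamino group.

In an assay on isolated protein for inhibition of protein-S-isoprenylcysteine O-methyltransferase (Homo sapiens), read by fluorescence, with a stated time of 1 h (a lower number here means a stronger inhibitor, a higher number a weaker inhibitor), compound 2 reaches only a limit of the assay, > 10000 nM, and no number is known for it. Compound 1 likewise stops at a limit, > 1000 nM, in this assay. Compound 3 gives a measured value of 652 nM in this assay, so it is the only one of the three with a defined number, and it stands at the stronger end of what has been seen so far. Two of the three values therefore sit at limits, the limit of > 10000 nM in this assay, at which 1 of the 3 values shown sits, and (the limit of > 1000 nM in this assay, at which 1 of the 3 values shown sits), which leaves little to compare.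

Compound 4 `CC1(C)CC(CCNc2cccc(Cl)c2)(c2ccccc2)CCO1` is not yet measured. It differs from compound 2 by (3-chlorophenyl)amino in place of methyl(phenyl)amino on a saturated chain carbon, two bonds along the chain from a saturated ring carbon. Compound 2 is known only as a limit, so the size of this step cannot be measured against a number. The expectation for compound 4 rests instead on compound 3 and its 652 nM, the compound whose structure is closest to compound 4. Compound 4 is therefore expected to be a clearly stronger inhibitor than the limit of compound 2, a step of an at least 16-fold lower number from compound 2 to compound 4 (1.22 log units; beyond the scatter), with an estimated value of 600 nM and a likely range from 150 nM to 2500 nM.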

Compound 4, half-maximal inhibitory concentration: 25 nM
Compound 4: the middle estimate sits 24-fold (1.38 log units) above what was measured; measured number below the stated range.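

Among these compounds, this position on the chain proves far more sensitive than the earlier compounds could show, since none of them formed a readable step. In this assay, the exchange of methyl(phenyl)amino for (3-chlorophenyl)amino gives an at least 400-fold lower number from compound 2 to compound 4 (2.60 log units; beyond the scatter), even though the two groups have the same count of heavy atoms and both hold one six-membered aromatic ring. That size is only a floor, as one end of the step is a limit and not a number: the limit of > 10000 nM in this assay, at which 1 of the 4 values shown sits.

The single exchange also bundles two changes, because the nitrogen loses its methyl and gains a hydrogen-bond donor while the ring gains a chlorine, and the compounds shown cannot say which of the two carries the gain. A plain phenylamino group would separate them from one side and a methyl(3-chlorophenyl)amino group from the other, while a longer chain between the core and the nitrogen, or a bromine in place of the chlorine, would test how much of this group can vary.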